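Dropping a Methoxy Group: A Small Expected Step

This account rests on a few compounds, and the source may have more. Where it says the series, first, only, none or still open, it means among the compounds named here.

Of the compounds shown here, three have been measured in a functional assay on a cell-free system (Platelet, plasma, Oryctolagus cuniculus) for inhibition, with a stated time of 5 min, at 37 degrees C; a higher number here means a weaker inhibitor, a lower number a stronger inhibitor. Compound 1, `COc1ccc(/C=C/C(=O)O)cc1OC(=O)c1nc(C)c(C)nc1C`, gives 41800 nM in this assay. Compound 2, `Cc1nc(C)c(C(=O)Oc2cccc(/C=C/C(=O)O)c2)nc1C`, gives 26400 nM in this assay. Compound 2 arises from compound 1 by a single change, (hydrogen in place of methoxy on an aromatic carbon), and that change gave a 1.6-fold lower number from compound 1 to compound 2 (0.20 log units; within the scatter). Compound 3, `CCOC(=O)/C=C/c1ccc(OC(=O)c2nc(C)c(C)nc2C)c(OC)c1`, gives 58400 nM in this assay. Its gap to compound 1 lies within the scatter of repeated measurements, while its gap to compound 2 lies beyond it. How the core of compound 3 differs from the core of compound 1 is not broken down here.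

Compound 4, `CCOC(=O)/C=C/c1ccc(OC(=O)c2nc(C)c(C)nc2C)cc1`, has not yet been measured. It differs from compound 3 by hydrogen in place of methoxy on an aromatic carbon. Among the compounds with values here, this is the same kind of change as the one from compound 1 to compound 2, but the surroundings of the place differ: in compound 1 the place is para to a 2-carboxyethenyl group, whereas in compound 3 it is meta to a 2-(ethoxycarbonyl)ethenyl group. For compound 4 a similarly small step is expected, a 1.5-fold lower number from compound 3 to compound 4 (0.16 log units; within the scatter), resting on the earlier step of a 1.6-fold lower number from compound 1 to compound 2 (0.20 log units; within the scatter), which stayed within the scatter. Compound 4 is therefore expected to give about 40000 nM in this assay, with a plausible range from 15000 nM to 100000 nM.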

Compound 4, half-maximal inhibitory concentration: 24400 nM
Compound 4: the middle estimate sits 1.6-fold (0.21 log units) above what was measured; the measured number falls inside the stated range.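

Putting hydrogen in place of methoxy gave a 2.4-fold lower number from compound 3 to compound 4 (0.38 log units; beyond the scatter) in this assay, a step that stands clear of the usual variation between repeated measurements, whereas the same change on the other core stayed inside it: a 1.6-fold lower number from compound 1 to compound 2 (0.20 log units; within the scatter). Even so, a difference between the two cores cannot be claimed, since the gap between the steps is no larger than two such steps would show by chance: the same change on two cores in this assay, a 1.6-fold lower number (0.20 log units; within the scatter) from compound 1 to compound 2 and a 2.4-fold lower number (0.38 log units; beyond the scatter) from compound 3 to compound 4, 1.5-fold (0.18 log units) apart, within the scatter of two such steps. This means the result on one core gives a fair guide to the result on the other, and the larger step on the core of compound 3 should not be read as a real special feature of that core, but two pairs of compounds cannot show that the change would behave the same way on further cores, nor do they explain why the numbers come out as they do.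

The compounds shown leave open what other small groups would do at this place on the ring, such as a hydroxyl group, a fluorine atom or an ethoxy group. They also leave open whether the step would hold if an amide or a longer chain on the ester stood at the end of the 2-(ethoxycarbonyl)ethenyl group.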